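Benzyl ether substituent exchanges and tolerated concentration

The compounds below may be only part of what the source reports. "The series", "measured", "known", "first", "only" and "open" are said of these compounds alone.

Compound 1 `O=c1c(OCc2ccccc2Br)c(-c2ccccc2)oc2cc(O)cc(O)c12` is tolerated in an ADME assay on Huh-5-2 cells (Homo sapiens) for cytotoxicity, read by WST assay, with a stated time of 3 days (a lower number here means that less compound is tolerated, a higher number that more compound is tolerated), at 12000 nM. Compound 2 `N#Cc1ccccc1COc1c(-c2ccccc2)oc2cc(O)cc(O)c2c1=O` reaches the limit of this assay at > 100000 nM, a limit and not a number. The measured step of an at least 8.3-fold higher number from compound 1 to compound 2 (0.92 log units; beyond the scatter), cyano in place of bromo on an aromatic carbon, ends at the limit of > 100000 nM in this assay, at which 1 of the 2 values shown sits, so compound 2 stands at the top of the numbers shown and is known only as a limit. Compound 3 `O=c1c(OCc2ccccc2[N+](=O)[O-])c(-c2ccccc2)oc2cc(O)cc(O)c12` differs from compound 2 by nitro in place of cyano on an aromatic carbon. Among the measured compounds shown here, no measured step covers this exchange; the single precedent, the bromo-to-cyano step, moved the tolerated concentration upward and past the limit. In this assay no step beyond the scatter is expected for compound 3. Compound 3 is expected at 100000 nM, within 30000 nM to 300000 nM, and most likely reported again only as a limit. The step of a number no higher from compound 2 to compound 3 (the limit leaves the size open) is expected to be essentially flat.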

Compound 3, half-maximal cytotoxic concentration: 51000 nM
The estimate for compound 3 lay 2.0-fold (0.29 log units) above the measured number; measured number inside the range.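

Nitro in place of bromo gives a 4.3-fold higher number from compound 1 to compound 3 (0.63 log units; beyond the scatter). This is a second exchange of bromo on this aromatic carbon, ortho to a large group, that moves the number upward in this assay, and here the size of the move can be read as a number. Going by these compounds, for cyano to nitro, the printed step is an at least 1.9-fold lower number from compound 2 to compound 3 (0.29 log units; that floor lies within the scatter) and its true size stays unknown, since compound 2 is held only as a limit: the limit of > 100000 nM in this assay, at which 1 of the 3 values shown sits.

The compounds shown leave open how an amine or a carboxylic acid on this same aromatic carbon would stand in this assay. Also open, on these data alone, is whether the nitro and cyano results carry over when either group sits on a different carbon of that aromatic ring.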